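Anilino and benzylamino variants on a tricyclic quinone core

This account rests on a few compounds, and the source may have more. Where it says the series, first, only, none or still open, it means among the compounds named here.

Measured so far:
compound 1, `O=C1C=C(NCc2ccccc2)C(=O)c2c1nc1n2[C@H]2OC[C@@H](O)[C@H]2OC1` — > 8000 nM
compound 2, `O=C1C(Nc2ccccc2F)=CC(=O)c2c1nc1n2[C@H]2OC[C@@H](O)[C@H]2OC1` — 9820 nM
compound 3, `O=C1C(N2CCC2)=CC(=O)c2c1nc1n2[C@H]2OC[C@@H](O)[C@H]2OC1` — > 16000 nM

In a functional assay on HeLa cells (Homo sapiens) for inhibition, read by sulforhodamine B assay (a higher number here means a weaker inhibitor, a lower number a stronger inhibitor), compound 1 gives only a limit, > 8000 nM, so its true value is not known from the numbers shown. Among the measured compounds shown here, compound 2 is the only member of the series with a numerical value in this assay, 9820 nM. For the measured compounds named here, compound 3 gives only a limit in this assay, > 16000 nM; the evidence the limit of > 16000 nM in this assay, at which 1 of the 3 values shown sits, marks that floor, as the limit of > 8000 nM in this assay, at which 1 of the 3 values shown sits, marks the one for compound 1. Going by the values given here, the single measured step, an at least 1.6-fold higher number from compound 2 to compound 3 (0.21 log units; that floor lies within the scatter), lies within the scatter and concerns a different exchange, so it does not bear on the change now considered.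

Compound 4, `Cc1ccc(NC2=CC(=O)c3nc4n(c3C2=O)[C@H]2OC[C@@H](O)[C@H]2OC4)cc1C`, differs from compound 1 by 3,4-dimethylphenyl in place of benzyl on an amine nitrogen. Among the compounds with values here, no measured step covers this exchange. Compound 4 carries an arylamino group, as does compound 2, and in this assay compound 2 gives 9820 nM. Compound 1 with benzylamino gives only a limit in this assay. Compound 4 is therefore expected near the region of compound 2, with a step that the limit leaves unreadable from compound 1 to compound 4 that cannot be judged against the scatter since compound 1 is a limit. The estimate for compound 4 in this assay is 9000 nM, between 3000 nM and 30000 nM.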

Compound 4, half-maximal inhibitory concentration: 2690 nM
For compound 4 the middle estimate is 3.3-fold (0.52 log units) above the measured one; the whole stated range lies above it.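

In this assay, among the compounds shown here, (3,4-dimethylphenyl)amino in place of benzylamino on the double-bonded ring carbon gives an at least 2.9-fold lower number from compound 1 to compound 4 (0.47 log units; beyond the scatter), the first step that lies beyond the scatter. This shows that the group on this amine nitrogen can shift the read-out on the core of compound 1, and that an arylamino group there gives the lower number of this pair. Compound 1 gives only a limit, so the step is a floor and its true size remains unknown: the limit of > 8000 nM in this assay, at which 1 of the 4 values shown sits.

The step combines two changes, the loss of the benzyl methylene and the arrival of the methyl groups on the ring, and a plain phenylamino or a 4-methoxyphenylamino group on the same core would begin to separate these contributions. Going by these compounds, compound 2 also carries an arylamino group, but it differs from compound 4 in more than one place, so whether the 3,4-dimethylphenyl group or the placement of the amine on the core matters more remains open.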